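Phenyl in place of 3,4-diethoxyphenyl: a step in the series

The compounds below may be only part of what the source reports. "The series", "measured", "known", "first", "only" and "open" are said of these compounds alone.

In a functional assay on DLD-1 cells (Homo sapiens) for cytotoxicity, read by MTT assay (a higher number here means a weaker inhibitor, a lower number a stronger inhibitor), compound 1 `COc1cc(/C=C/C(=O)C(=Cc2ccc(OC)c(OC)c2)C(=O)/C=C/c2ccc(O)c(OC)c2)ccc1O` gives 3070 nM, compound 2 `COc1cc(/C=C/C(=O)C(=Cc2ccc(O)cc2)C(=O)/C=C/c2ccc(O)c(OC)c2)ccc1O` gives 4080 nM and compound 3 `CCOc1ccc(C=C(C(=O)/C=C/c2ccc(O)c(OC)c2)C(=O)/C=C/c2ccc(O)c(OC)c2)cc1OCC` gives 4120 nM. Compound 3 thus stands within the scatter of both others. Compound 4 `COc1cc(/C=C/C(=O)C(=Cc2ccccc2)C(=O)/C=C/c2ccc(O)c(OC)c2)ccc1O` differs from compound 3 on a double-bonded chain carbon bound to a double-bonded chain carbon: phenyl in place of 3,4-diethoxyphenyl on a double-bonded chain carbon bound to a double-bonded chain carbon. Three measured exchanges at this place bear on it: a 1.3-fold higher number from compound 1 to compound 2 (0.12 log units; within the scatter), a 1.3-fold higher number from compound 1 to compound 3 (0.13 log units; within the scatter) and a 1.0-fold higher number from compound 2 to compound 3 (0.00 log units; within the scatter). All stay within the scatter, although none of them involves an unsubstituted phenyl. The expected step is a 1.1-fold lower number from compound 3 to compound 4 (0.04 log units; within the scatter), with no change expected beyond the scatter. For compound 4 the estimate is 3800 nM, with an expected range of 2000 nM to 7000 nM.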

Compound 4, half-maximal inhibitory concentration: 5450 nM
Compound 4: middle estimate off by 1.4-fold (0.16 log units), on the low side, within the range that was stated.
By their numbers in this assay, from the lowest: compounds 1, 2, 3 and 4 (each within the scatter of the next).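

Unsubstituted phenyl now extends the exchanges on this double-bonded chain carbon bound to a double-bonded chain carbon: in this assay, losing the ring's substituents stays within the scatter, with a 1.3-fold higher number from compound 3 to compound 4 (0.12 log units; within the scatter) and a 1.8-fold higher number from compound 1 to compound 4 (0.25 log units; within the scatter). Hydrogen in place of hydroxy on an aromatic carbon also stays within the scatter, with a 1.3-fold higher number from compound 2 to compound 4 (0.13 log units; within the scatter), so none of these substituents is needed for a number in this range. Nothing available here accounts for this result.

On these data alone, whether an amine, a carboxylic acid or a longer alkoxy chain on this ring would move the number beyond the scatter remains open.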